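Chloro removal on the pendant aryl of compound 1

The source may report more compounds than this note shows. Statements on the series, on what has been measured and on what is new or still open speak of the compounds shown alone.

Two members of the series have numbers in a functional assay on NCI/ADR-RES cells (Homo sapiens) for inhibition (on this read-out higher numbers stand for weaker inhibition of growth and lower numbers for stronger inhibition of growth), so far. Compound 1 `COc1cc(/C=C/C(=O)c2cccc(-n3cc(-c4ccc(Cl)cc4)[nH]c3=O)c2)cc(OC)c1OC` gives 2360 nM there, and compound 2 `O=C(/C=C/c1cccc(O)c1)c1cccc(-n2cc(-c3ccccc3)[nH]c2=O)c1` gives 3730 nM in this assay. Compound 1 and compound 2 lie within the scatter of each other, so neither stands apart on the numbers at hand; compound 2 also differs from compound 1 at more than one place, so no single step can be read from that pair.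

The next compound, compound 3 `COc1cc(/C=C/C(=O)c2cccc(-n3cc(-c4ccccc4)[nH]c3=O)c2)cc(OC)c1OC`, is not yet measured in this assay. It keeps the shared core of compound 1 and differs only in one change: hydrogen in place of chloro on an aromatic carbon. Nothing measured in the series isolates this change, so the size of the step rests on general experience with a single halogen-to-hydrogen swap on an aryl group: a modest loss is the more common outcome, but a step that stays within the scatter is fully possible.

The expected step in this assay is a 1.4-fold higher number from compound 1 to compound 3 (0.13 log units; within the scatter), a small move toward weaker growth inhibition. Compound 3 is therefore estimated at 3200 nM in this assay, with a range from 1300 nM to 8000 nM.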

Compound 3, concentration for 50% growth inhibition: 1100 nM
Compound 3: middle estimate off by 2.9-fold (0.46 log units), on the high side; measured number outside the range, below it.
By their numbers in this assay, from the lowest: compound 3; then compounds 1 and 2 (each within the scatter of the next).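

The change from 4-chlorophenyl to phenyl, on an aromatic carbon para to a large group, gives the series its first single-place comparison, and in this assay it reads as a 2.1-fold lower number from compound 1 to compound 3 (0.33 log units; beyond the scatter) and so points toward stronger inhibition of growth. On this shared core, the chloro is therefore not required for growth inhibition on this read-out, and the loss of this one heavy atom is accompanied by a lower number rather than the small upward move or flat result that the earlier numbers left possible. No measurement at hand accounts for the direction of this step.

A single pair leaves open whether the lower number belongs to the hydrogen specifically or whether other groups on the same aromatic carbon, such as fluoro, methoxy, an amine or a carboxylic acid, would match or pass it in this assay. As far as these compounds go, it also remains open whether the same swap gives a step of this size and direction when the rest of the compound 1 structure is changed.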